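A few compounds are considered here, and "the series" means these few. Any claim that something is new, unique, unknown or untested is made for them only; others in the source may bear on it.

Compound 3 `CC(=O)c1cnc(C(=O)CCCCCCc2ccccc2)o1` gives 2 nM in an assay (Rattus norvegicus) for inhibition of Fatty-acid amide hydrolase 1 (Homo sapiens) (a lower number here means a stronger inhibitor, a higher number a weaker inhibitor), and has the lowest number of the three compounds measured. Compound 1 `NC(=O)c1cccc(-c2cnc(C(=O)CCCCCCc3ccccc3)o2)c1` gives 6 nM in this assay, and compound 2 `Nc1ccc(-c2cnc(C(=O)CCCCCCc3ccccc3)o2)cc1` gives 90 nM. The step of a 3.0-fold lower number from compound 1 to compound 3 (0.48 log units; beyond the scatter) and the step of a 45-fold lower number from compound 2 to compound 3 (1.65 log units; beyond the scatter) both end at compound 3, so the acetyl group on the shared core is linked to the strongest inhibition seen so far.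

Compound 4 `O=C(CCCCCCc1ccccc1)c1ncc(Cl)o1` carries chloro in place of acetyl on an aromatic carbon. Within the data shown here, no measured step exchanges one small group for another at this position; the three known steps all replace a substituted phenyl ring with another group. Of these, a 3.0-fold lower number from compound 1 to compound 3 (0.48 log units; beyond the scatter) is the only one that leaves an acetyl group in place, and it was modest. Since the hydrogen-bond acceptor of the acetyl group is lost in compound 4, a modest step in the direction of a higher number is expected in this assay, a 4.0-fold higher number from compound 3 to compound 4 (0.60 log units; beyond the scatter). Compound 4 is therefore estimated at 8 nM, in a range from 2 nM to 30 nM.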

Compound 4, inhibition constant: 5 nM
Beside the measured number, compound 4's estimate is 1.6-fold (0.20 log units) above it, and the stated range covers the measured number.
By their numbers in this assay, from the lowest: compound 3; then compounds 4 and 1 (each within the scatter of the next); then compound 2.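

In this assay the step of a 2.5-fold higher number from compound 3 to compound 4 (0.40 log units; beyond the scatter) shows that this position, next to the ring oxygen, keeps a low number when acetyl gives way to the much smaller chloro, which has no hydrogen-bond acceptor, although the change is beyond the scatter. The step of an 18-fold lower number from compound 2 to compound 4 (1.26 log units; beyond the scatter) sets chloro clearly apart from 4-aminophenyl, while the step of a 1.2-fold lower number from compound 1 to compound 4 (0.08 log units; within the scatter) leaves chloro and 3-carbamoylphenyl unresolved, so a substituted phenyl ring at this position need not give a higher number than a single atom. No measurement shown explains these steps.

On these data alone, how a bare hydrogen, a nitrile or a methyl ester at this position would compare with acetyl and chloro remains open. So does whether an unsubstituted phenyl or a 3-aminophenyl would sit nearer compound 1 or compound 2.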